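Moving a fluorine in a series at the assay limit

The source may report more compounds than this note shows. Statements on the series, on what has been measured and on what is new or still open speak of the compounds shown alone.

In a toxicity assay on HEK-293T cells (Homo sapiens) for inhibition, read by MTT assay, with a stated time of 24 h (a lower number here means that less compound is tolerated, a higher number that more compound is tolerated), compound 1 `O=c1oc2ccccc2c(N2CCN(c3cccc(Cl)c3Cl)CC2)c1CO` gives > 50000 nM as a limit and not a number. Compound 2 `COc1cccc(N2CCN(c3c(CO)c(=O)oc4ccccc34)CC2)c1` gives > 50000 nM as a limit too. Compound 3 `O=c1oc2ccccc2c(N2CCN(c3ccccc3F)CC2)c1CO` gives > 50000 nM and this is likewise only a limit.

Compound 4 `O=c1oc2ccccc2c(N2CCN(c3ccc(F)cc3)CC2)c1CO` differs from compound 3 as follows: 4-fluorophenyl in place of 2-fluorophenyl on an amine nitrogen in a ring so that 4-fluorophenyl stands in place of 2-fluorophenyl on an amine nitrogen in a ring. Among the measured compounds shown here, the steps that bear on this change replace the group at the same place: a step that the two limits leave unreadable from compound 1 to compound 3 and a step that the two limits leave unreadable from compound 2 to compound 3 and also a step that the two limits leave unreadable from compound 1 to compound 2 and none of them has a readable size. The expectation therefore rests on the limit of > 50000 nM in this assay, at which 3 of the 3 values shown sit, and on nothing finer. No step beyond the scatter is expected, and the estimated change is a step that the limit leaves unreadable from compound 3 to compound 4 with no direction favoured. The estimated value for compound 4 is 60000 nM within an expected range of 30000 nM to 120000 nM and this assay may well report only a limit again.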

Compound 4, half-maximal cytotoxic concentration: > 50000 nM
Compound 4 gave a limit, no number; the forecaster's own chance of this, stated with the estimate: 85%; the middle value is on the limit's open side.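

In this assay compound 4 gives > 50000 nM, a limit and not a number. No step from compound 1, compound 2 or compound 3 to compound 4 can be read: the limit of > 50000 nM in this assay, at which 4 of the 4 values shown sit.

The compounds shown leave open how much of each compound is actually tolerated, and whether 4-fluorophenyl and 2-fluorophenyl differ at all.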